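Swapping the aminophenyl for a dichlorophenyl on the enone

The compounds below may be only part of what the source reports. "The series", "measured", "known", "first", "only" and "open" are said of these compounds alone.

Of the compounds shown here, two have been measured in a functional assay on 786-0 cells (Homo sapiens) for cytotoxicity, read by sulforhodamine B assay, with a stated time of 48 h, tested at 0.01 uM; on this read-out higher numbers stand for a weaker effect at the one concentration tested and lower numbers for a stronger effect. Compound 1 `COc1ccc(-c2cc(/C=C/C(=O)c3ccc(N)cc3)[nH]n2)cc1` gives 96%, and compound 2 `COc1cc(-c2cc(/C=C/C(=O)c3ccc(N)cc3)[nH]n2)cc(OC)c1OC` gives 92%; the two values lie within the scatter of each other, so neither stands apart. Compound 3 `COc1cc(-c2cc(/C=C/C(=O)c3ccc(Cl)c(Cl)c3)[nH]n2)cc(OC)c1OC` is not yet measured; it differs from compound 2 by 3,4-dichlorophenyl in place of 4-aminophenyl on a carbonyl carbon. Among the measured compounds shown here, nothing among the measured compounds shows how this exchange acts, so compound 3 is expected to show a step of a number 1 percentage points lower from compound 2 to compound 3 (within the scatter), not beyond the scatter. Compound 3 is estimated at 91%, within 78% to 104%.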

Compound 3, a percentage reported as activity, at one concentration (the size of the read-out at that concentration, not a potency): 95%
Beside the measured number, compound 3's estimate is 4 percentage points below it; the measured number falls inside the stated range.
By their numbers in this assay, from the lowest: compounds 2, 3 and 1 (each within the scatter of the next).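

On the carbonyl carbon, 3,4-dichlorophenyl in place of 4-aminophenyl gives in this assay a step of a number 3 percentage points higher from compound 2 to compound 3 (within the scatter), so this first change at the position does not move the read-out beyond the scatter. The hydrogen-bond donor and acceptor counted on the leaving group are absent from the entering one, yet the read-out separates neither compound at this single concentration. No available measurement accounts for this result. The compounds shown leave open whether the same exchange behaves alike on the core of compound 1. They also leave open whether a carboxylic acid or a morpholine on this carbonyl carbon would shift the read-out.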